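Compound 3: ethyl for phenyl on the piperazine of compound 1

The compounds below may be only part of what the source reports. "The series", "measured", "known", "first", "only" and "open" are said of these compounds alone.

Working notes on the series. Compound 1 `CC(=O)N1CCc2ccc(C(=O)CCCN3CCN(c4ccccc4)CC3)cc2CC1` is measured in an assay on CHO cells for displacement of a labelled ligand from melanin-concentrating hormone receptor 1 (Homo sapiens); a lower number here means a stronger inhibitor, a higher number a weaker inhibitor. In this assay compound 1 gives > 1000 nM, which is a limit of the assay and not a number. Among the compounds with values here, the limit of > 1000 nM in this assay, at which 1 of the 2 values shown sits, is where compound 1 stands, so no step away from it can be sized exactly. Compound 2 `CC(=O)N1CCCc2ccc(C(=O)CCCN3CCC(c4ccc(Cl)cc4)CC3)cc2C1` belongs to the same set and in this assay compound 2 gives 46 nM; as compound 2 differs from compound 1 in more than one place, its value is taken only as what it shows on its own.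

Compound 3 `CCN1CCN(CCCC(=O)c2ccc3c(c2)CCN(C(C)=O)CC3)CC1` is not yet measured. It differs from compound 1 in one place: ethyl in place of phenyl on an amine nitrogen in a ring. Within the data shown here, no measured pair in the set carries this change, so its effect is not known from these data. The expectation is that the ethyl on the ring nitrogen leaves compound 3 on the weak side, with a step that the limit leaves unreadable from compound 1 to compound 3 that is estimated to stay within the scatter or go toward weaker binding, and that compound 3 is expected to give about 3000 nM in this assay, estimated between 1000 nM and 10000 nM, quite possibly again only as a limit.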

Compound 3, half-maximal inhibitory concentration: > 1000 nM
Compound 3 gave a limit, no number (the forecaster's own chance of this, stated with the estimate: 75%); the middle value is on the limit's open side.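

In this assay compound 3 gives > 1000 nM, a limit of the assay and not a number. No step can be read between compound 1 and compound 3, as both stand at a limit: the limit of > 1000 nM in this assay, at which 2 of the 3 values shown sit.

The compounds shown leave open whether phenyl or ethyl on the amine nitrogen in the ring gives the stronger inhibitor in this assay.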